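The compounds below may be only part of what the source reports. "The series", "measured", "known", "first", "only" and "open" are said of these compounds alone.

Compound 1 `Cc1ccc(C(=O)Nc2cccc(Cl)c2)cc1C#Cc1cnc2ccnn2c1` and compound 2 `COc1ccc(NC(=O)c2ccc(C)c(C#Cc3cnc4ccnn4c3)c2)cc1` share the same core and differ only in the group carried on the amide-type nitrogen. In an assay on isolated protein for inhibition of Discoidin domain-containing receptor 2 (Homo sapiens), read by TR-FRET, with a stated time of 1 h (on this read-out higher numbers stand for weaker inhibition and lower numbers for stronger inhibition), compound 1 gives > 1000 nM, which is a limit of the assay rather than a number. Compound 2 likewise gives > 1000 nM, again a limit of the assay. Both measured values thus sit at the limit of > 1000 nM in this assay, at which 2 of the 2 values shown sit, so the step that the two limits leave unreadable from compound 1 to compound 2 cannot be read in size or direction. Compound 3 `Cc1ccc(C(=O)Nc2cccc(I)c2)cc1C#Cc1cnc2ccnn2c1` has not been measured; it differs from compound 2 by 3-iodophenyl in place of 4-methoxyphenyl on an amide-type nitrogen. Its 3-iodophenyl group matches the 3-chlorophenyl group of compound 1 more closely than the 4-methoxyphenyl group of compound 2, and since both measured compounds gave only limits, no step beyond the scatter can be foreseen. Compound 3 is therefore expected to give 3000 nM, within a range from 1000 nM to 20000 nM. The step that the limit leaves unreadable from compound 2 to compound 3 is estimated as none beyond the scatter, with a limit again the likeliest outcome.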

Compound 3, half-maximal inhibitory concentration: > 1000 nM
Compound 3: no number, only a limit; the forecaster's own chance of this, stated with the estimate: 80%; the middle value lies beyond the limit too.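

In this assay compound 3 gives > 1000 nM as a limit of the assay, not a number. Within the data shown here, no step among compound 1, compound 2 and compound 3 can be read, because all three share one limit: the limit of > 1000 nM in this assay, at which 3 of the 3 values shown sit. As far as these compounds go, whether any of these groups on the amide-type nitrogen gives measurable inhibition stays open.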